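Where a Methyl Goes on Compound 1

A few compounds are considered here, and "the series" means these few. Any claim that something is new, unique, unknown or untested is made for them only; others in the source may bear on it.

Among the measured compounds shown here, in a functional assay on NCI-H460 cells (Homo sapiens) for antiproliferative activity (on this read-out lower numbers stand for stronger inhibition of growth and higher numbers for weaker inhibition of growth), compound 1 `Oc1cc(-c2ccc3ccccc3c2)nc2ncccc12` gives 3800 nM, the higher of the two numbers measured so far. Compound 2 `Cc1ccnc2nc(-c3ccc4ccccc4c3)cc(O)c12` gives 1050 nM, and the move between them is a 3.6-fold lower number from compound 1 to compound 2 (0.56 log units; beyond the scatter), a modest step made by methyl in place of hydrogen on an aromatic carbon. Compound 3 `Cc1ccc2c(O)cc(-c3ccc4ccccc4c3)nc2n1` has not yet been measured. It differs from compound 1 by methyl in place of hydrogen on an aromatic carbon, with the methyl next to the ring nitrogen. For the measured compounds named here, only one measured step bears on this change, and compound 2 carries its methyl elsewhere on the core, so its a 3.6-fold lower number from compound 1 to compound 2 (0.56 log units; beyond the scatter) is a loose guide. A modest drop in the same direction is expected, though a change within the scatter remains possible. The expected change is a 1.9-fold lower number from compound 1 to compound 3 (0.28 log units; within the scatter). For compound 3 the estimate is 2000 nM, with an expected range from 700 nM to 5000 nM.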

Compound 3, concentration for 50% growth inhibition: 3800 nM
The estimate for compound 3 lay 1.9-fold (0.28 log units) below the measured number, within the range that was stated.
By their numbers in this assay, from the lowest: compound 2; then compounds 1 and 3 (each within the scatter of the next).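

In this assay, a methyl next to the ring nitrogen gives no change at the digits printed from compound 1 to compound 3 (within the scatter), so at this position the added methyl brings no measurable gain. The same swap of hydrogen for methyl at the aromatic carbon used in compound 2 gave a 3.6-fold lower number from compound 1 to compound 2 (0.56 log units; beyond the scatter), which shows that the earlier drop does not carry over to every aromatic carbon of the shared core, and that across these three compounds the place of the methyl matters. Nothing in the data available here explains the difference between the two places.

From the compounds shown here alone, a single methyl says little about other groups, so it remains open whether an amine, a methoxy group or a longer chain next to the ring nitrogen would move the number. Going by these compounds, it also remains open how a methyl would behave on the other aromatic carbons of the core.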